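The compounds below may be only part of what the source reports. "The series", "measured", "known", "first", "only" and "open" are said of these compounds alone.

Compound 1 `CCCCCOC(=O)N1CCN(C(=O)[C@H](CCC(=O)O)NC(=O)c2cc(N3CCC(C(=O)N(CC)CC)CC3)nc(-c3ccccc3)n2)CC1` — in an ADME assay on microsomes from liver (Rattus norvegicus) for metabolic stability (a lower number here means that less of the compound is left, a higher number that more of the compound is left), compound 1 gives > 80%, which is a limit of the assay.
Compound 2 `CCCCCOC(=O)N1CCN(C(=O)[C@H](CCC(=O)O)NC(=O)c2cc(N3CCC(C(=O)NCC)CC3)nc(-c3ccccc3)n2)CC1` — in this assay compound 2 gives > 80%, again a limit.
Compound 3 `CCCCCOC(=O)N1CCN(C(=O)[C@H](CCC(=O)O)NC(=O)c2cc(N3CCC(COC)CC3)nc(-c3ccccc3)n2)CC1` — in this assay compound 3 gives > 80%, also a limit.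

Compound 3 therefore stands where every value shown sits: the limit of > 80% in this assay, at which 3 of the 3 values shown sit. Compound 4 `CCCCCOC(=O)N1CCN(C(=O)[C@H](CCC(=O)O)NC(=O)c2cc(N3CCC(N4CCCC4)CC3)nc(-c3ccccc3)n2)CC1` differs from it by pyrrolidin-1-yl in place of methoxymethyl on a saturated ring carbon. The steps that touch this ring carbon, a step that the two limits leave unreadable from compound 1 to compound 3 and a step that the two limits leave unreadable from compound 2 to compound 3, cannot be read, and the same holds for a step that the two limits leave unreadable from compound 1 to compound 2, so no size of change has yet been seen anywhere in this set. The step from compound 3 to compound 4 is accordingly expected to be a step that the limit leaves unreadable from compound 3 to compound 4 in this assay. Compound 4 is thus estimated at 85%, in the range from 65% to 97%.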

Compound 4, percent of the compound remaining: > 80%
Compound 4 ended at the assay's limit; the forecaster's own chance of this, stated with the estimate: 65%; the middle value does not contradict the limit.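

In this assay compound 4 gives > 80%, a limit of the assay, so its steps from compound 1, compound 2 and compound 3 cannot be read. The compounds shown leave open whether any group on this saturated ring carbon changes the read-out, as every value sits at one limit: the limit of > 80% in this assay, at which 4 of the 4 values shown sit.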